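Dropping One Trifluoromethyl From a Bis-Trifluoromethyl Urea

A few compounds are considered here, and "the series" means these few. Any claim that something is new, unique, unknown or untested is made for them only; others in the source may bear on it.

Three measured compounds share a core and differ only in small groups on two outer rings. In a functional assay on NCI-H460 cells (Homo sapiens) for inhibition, read by sulforhodamine B assay, with a stated time of 48 h, tested at 100 uM (on this read-out lower numbers stand for a stronger effect and higher numbers for a weaker effect at the one concentration tested), compound 1 `O=C(Nc1cccc(-n2cc(-c3ccncc3)c(-c3cc(O)cc(Cl)c3)n2)c1)Nc1ccc(Cl)c(C(F)(F)F)c1` gives -52%. Compound 2 `COc1cc(Cl)cc(-c2nn(-c3cccc(NC(=O)Nc4ccc(Cl)c(C(F)(F)F)c4)c3)cc2-c2ccncc2)c1` gives -62%, and the step of a number 10 percentage points lower from compound 1 to compound 2 (within the scatter) shows that methyl in place of hydrogen on an oxygen on an aromatic ring changes little. Compound 3 `COc1cc(Cl)cc(-c2nn(-c3cccc(NC(=O)Nc4cc(C(F)(F)F)cc(C(F)(F)F)c4)c3)cc2-c2ccncc2)c1` gives -84%, the lowest of the three numbers, beyond the scatter from both compound 2 and compound 1.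

Compound 4 `COc1cc(Cl)cc(-c2nn(-c3cccc(NC(=O)Nc4cccc(C(F)(F)F)c4)c3)cc2-c2ccncc2)c1` has not yet been measured. Compared with compound 3 the change is hydrogen in place of trifluoromethyl on an aromatic carbon. Going by the values given here, no measured step is of this kind: the one counted step, from compound 1 to compound 2, concerns another ring and lies within the scatter, so it gives no guide to the size of this change. The values of compound 2 and compound 3 show that the ring carrying two trifluoromethyl groups gives a lower number than the ring carrying one trifluoromethyl and one chlorine, though this is not a counted step. Among the compounds with values here, a weaker effect than compound 3 is expected because compound 2 gives -62% with only one trifluoromethyl on that ring. The step from compound 3 to compound 4 is estimated as a number 29 percentage points higher from compound 3 to compound 4 (beyond the scatter). Compound 4 is expected to give -55%, within a range from -85% to -25%.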

Compound 4, a percentage reported as activity, at one concentration (the size of the read-out at that concentration, not a potency): -48%
The estimate for compound 4 lay 7 percentage points below the measured number, within the range that was stated.
By their numbers in this assay, from the lowest: compound 3; then compounds 2, 1 and 4 (each within the scatter of the next, the first and the last beyond it).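

In this assay, removing one trifluoromethyl gives a number 36 percentage points higher from compound 3 to compound 4 (beyond the scatter) and counts as a large change, so what this position carries matters: this aromatic carbon, meta to a trifluoromethyl group, cannot simply be left bare without a clear loss of effect. Hydrogen in place of chloro on the same ring gives a number 14 percentage points higher from compound 2 to compound 4 (beyond the scatter) and is a more modest change, so in both pairs the compound with one trifluoromethyl and a hydrogen in place of the second group has the weaker effect, although the chloro and the second trifluoromethyl do not stand at the same place and their steps cannot be treated as a clean comparison of the two groups. No measurement here explains why either change has this effect.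

The compounds shown leave open whether a different group at this place, such as a nitrile, an amine or a carboxylic acid, would give a number closer to that of compound 3 or to that of compound 4. Because every number comes from one concentration, they also leave open how the compounds would rank in potency across a range of concentrations.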